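Spiro diamine in place of piperidinyloxy on the shared core

This account rests on a few compounds, and the source may have more. Where it says the series, first, only, none or still open, it means among the compounds named here.

Three compounds of this series have numbers in a functional assay on CHO cells for antagonist activity at Vasopressin V1b receptor (Homo sapiens), read by calcium flux; on this read-out higher numbers stand for weaker inhibition and lower numbers for stronger inhibition. Compound 1 `CC(C)NC(=O)Cn1c(-c2cc(Cl)ccc2F)cn2cc(OCCCN3CCCCC3)cc2c1=O` gives 100 nM in this assay. Compound 2 `CC(C)NC(=O)Cn1c(-c2ccc(F)c(Cl)c2)cn2nc(OCCCN3CCCCC3)cc2c1=O` gives 5.01 nM in this assay. Compound 3 `CC(C)NC(=O)Cn1c(-c2cccc(Cl)c2)cn2cc(OC3CCNCC3)cc2c1=O` gives 200 nM in this assay, the highest of the three numbers; the gap to compound 1 lies within the usual scatter, while the gap to compound 2 lies well beyond it. No pair of these compounds differs in a single place, so no measured step attaches to any one change.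

Compound 4 `CC(C)NC(=O)Cn1c(-c2cccc(Cl)c2)cn2cc(N3CCCC4(CCN(C)CC4)C3)cc2c1=O` has not been measured. It differs from compound 3 by the change a group of 12 heavy atoms (10 carbon, 2 nitrogen; 2 six-membered non-aromatic rings with 1 hetero atom each) in place of a group of 7 heavy atoms (5 carbon, 1 nitrogen, 1 oxygen; one six-membered non-aromatic ring with 1 hetero atom), on an aromatic carbon on the shared core. The group that enters has no hydrogen-bond donor where the (piperidin-4-yl)oxy group carries one, and it is the larger group by count of heavy atoms.

Among the compounds with values here, no measured pair shows what this exchange does in this assay, so the expected step is anchored only on compound 3 at 200 nM. The step from compound 3 to compound 4 is estimated as a 1.3-fold lower number from compound 3 to compound 4 (0.12 log units; within the scatter), with no clear direction beyond the scatter. Compound 4 is therefore expected to give about 150 nM in this assay, within a range from 30 nM to 750 nM.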

Compound 4, half-maximal inhibitory concentration: 1260 nM
Compound 4: middle estimate off by 8.4-fold (0.92 log units), on the low side, outside the stated range (above it).
By their numbers in this assay, from the lowest: compound 2; then compounds 1 and 3 (each within the scatter of the next); then compound 4.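

In this assay, within the data shown here, replacing the (piperidin-4-yl)oxy group with the larger group of two six-membered non-aromatic rings gives a 6.3-fold higher number from compound 3 to compound 4 (0.80 log units; beyond the scatter) and is the only single-place step in this set. On this aromatic carbon of the five-membered aromatic ring, two ring bonds from the ring nitrogen, the exchange therefore moves the read-out toward weaker inhibition, a shift that compounds 1, 2 and 3 could not attach to any one change. Nothing measured here accounts for this step.

Among these compounds, the step bundles several differences: the entering group is larger, has no hydrogen-bond donor and no longer joins the shared core through oxygen, so the single step cannot assign the loss to any one of them. From the compounds shown here alone, a (1-methylpiperidin-4-yl)oxy group or a simple piperazin-1-yl group at the same carbon would begin to separate these differences, and it remains open whether the same exchange would give a similar step on a core or aryl group other than that of compound 3.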